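This account rests on a few compounds, and the source may have more. Where it says the series, first, only, none or still open, it means among the compounds named here.

In a functional assay on SGC-7901 cells (Homo sapiens) for antiproliferative activity, read by MTT assay, with a stated time of 72 h (on this read-out higher numbers stand for weaker inhibition and lower numbers for stronger inhibition), compound 1 `COc1ccc(-c2ccc3ncn(-c4cc(OC)c(OC)c(OC)c4)c3c2)cc1O` gives 44 nM, the lowest number among the three measured compounds. Compound 2 `COc1cc(-n2cnc3ccc(-c4ccc([N+](=O)[O-])cc4)cc32)cc(OC)c1OC` gives 79 nM, and a 1.8-fold higher number from compound 1 to compound 2 (0.25 log units; within the scatter). Compound 3 `COc1cc(-n2cnc3ccc(-c4cccc(F)c4)cc32)cc(OC)c1OC` gives 2490 nM; here a 57-fold higher number from compound 1 to compound 3 (1.75 log units; beyond the scatter) and a 32-fold higher number from compound 2 to compound 3 (1.50 log units; beyond the scatter). Compound 4 `COc1ccc(-c2ccc3ncn(-c4cc(OC)c(OC)c(OC)c4)c3c2)cc1` differs from compound 1 by hydrogen in place of hydroxy on an aromatic carbon. Within the data shown here, no measured step exchanges only the hydroxy group; each of the three steps replaces the whole aryl group, so the weight of the hydroxy group alone remains unmeasured. The aryl change to the nitro compound left the number within the scatter, while the change to the fluoro compound raised it sharply, so he expects a small to moderate rise for compound 4, a 2.5-fold higher number from compound 1 to compound 4 (0.40 log units; beyond the scatter). He estimates compound 4 at 110 nM, within 40 nM to 400 nM.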

Compound 4, half-maximal inhibitory concentration: 82 nM
The estimate for compound 4 lay 1.3-fold (0.13 log units) above the measured number; low and high end bracket the measured number.
By their numbers in this assay, from the lowest: compounds 1, 2 and 4 (each within the scatter of the next); then compound 3.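

In this assay, among these compounds, hydrogen in place of hydroxy, ortho to the methoxy group, gives a 1.9-fold higher number from compound 1 to compound 4 (0.27 log units; within the scatter), the first reading of this single exchange, and it stays within the scatter. Methoxy in place of nitro gives a 1.0-fold higher number from compound 2 to compound 4 (0.02 log units; within the scatter), while 4-methoxyphenyl in place of 3-fluorophenyl gives a 30-fold lower number from compound 3 to compound 4 (1.48 log units; beyond the scatter), so the hydroxy group is not needed to stay clear of the much higher number of compound 3. Nothing available offers a reason for these numbers.

As far as these compounds go, whether an amine or a carboxylic acid in the place of the hydroxy group would keep the number in this range remains open.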